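The source may hold more compounds than are shown below. What is called first, only, known or untested is meant among the compounds shown, and "the series" means these compounds.

Of the compounds shown here, three built on one shared core have been tested in a functional assay on cells (Panel melanoma (Carcinoma cell lines), Homo sapiens) for inhibition, read by sulforhodamine B assay, with a stated time of 48 h; on this read-out lower numbers stand for higher toxicity in this test and higher numbers for lower toxicity in this test. Compound 1 `CN1CCN(CCCOc2cccc3nc(Nc4ccc(Cl)c(C(F)(F)F)c4)ccc23)CC1` gives 6700 nM, compound 2 `CN1CCN(CCCOc2cccc3nc(Nc4ccc(Cl)c(F)c4)ccc23)CC1` gives 6770 nM, and compound 3 `CN1CCN(CCCOc2cccc3nc(Nc4cc(Cl)cc(Cl)c4)ccc23)CC1` gives 6620 nM. Compound 3 holds the lowest of the three numbers, yet its gaps to compound 1 and to compound 2 both lie within the scatter, so the three stand level. Compound 4 `CN1CCN(CCCOc2cccc3nc(Nc4cccc(Cl)c4)ccc23)CC1` differs from compound 3 by hydrogen in place of chloro on an aromatic carbon meta to a chloro group. Among the measured compounds shown here, no measured step removes a halogen outright; the steps of a 1.0-fold higher number from compound 1 to compound 2 (0.00 log units; within the scatter), a 1.0-fold lower number from compound 1 to compound 3 (0.01 log units; within the scatter) and a 1.0-fold lower number from compound 2 to compound 3 (0.01 log units; within the scatter) all exchange halogens on that ring without moving the number beyond the scatter. The analyst therefore expects no step beyond the scatter, a 1.0-fold higher number from compound 3 to compound 4 (0.01 log units; within the scatter). Compound 4 is accordingly estimated at 6700 nM, within a range from 4000 nM to 11500 nM.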

Compound 4, concentration lethal to 50% of the cells: 6450 nM
For compound 4 the middle estimate is 1.0-fold (0.02 log units) above the measured one, within the range that was stated.
By their numbers in this assay, from the lowest: compounds 4, 3, 1 and 2 (each within the scatter of the next).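

In this assay, the loss of a chloro group with hydrogen entering in its place gives (a 1.0-fold lower number from compound 3 to compound 4 (0.01 log units; within the scatter)), so this ring tolerates an outright removal as well as the halogen exchanges seen earlier. Replacing the 4-chloro-3-fluorophenyl or the 4-chloro-3-(trifluoromethyl)phenyl with 3-chlorophenyl likewise gives (a 1.0-fold lower number from compound 2 to compound 4 (0.02 log units; within the scatter)) and (a 1.0-fold lower number from compound 1 to compound 4 (0.02 log units; within the scatter)). The compounds shown leave open whether an unsubstituted phenyl would hold this level, and whether an amine or a carboxylic acid on this ring would move the number. No measurement at hand accounts for this flat result.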